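A few compounds are considered here, and "the series" means these few. Any claim that something is new, unique, unknown or untested is made for them only; others in the source may bear on it.

The measured compounds:
- compound 1, `CC(C)Oc1cc(Oc2cnc(C(=O)N(C)C)nc2)cc(-c2nccc(=O)[nH]2)c1`: in an ADME assay on MDCK-II cells (Canis lupus familiaris) for permeability (a higher number here means that the compound crosses the layer faster, a lower number that the compound crosses the layer more slowly), compound 1 gives 7.1 10^-6 cm/s
- compound 2, `COC[C@H](C)Oc1cc(Oc2cnc(C(=O)N(C)C)nc2)cc(-c2nccc(=O)[nH]2)c1`: in this assay compound 2 gives "not determined" (no result reported), so no result is reported
- compound 3, `CN(C)C(=O)c1ncc(Oc2cc(OC3CCOC3)cc(-c3nccc(=O)[nH]3)c2)cn1`: in this assay compound 3 gives "not determined" (no result reported), so no result is reported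

Compound 1 stands alone with a number: it is the only one of the three for which this assay returned a value, and the two further entries, compound 2 and compound 3, carry no number at all. For the measured compounds named here, there is therefore no measured step between compounds to set the scale, and nothing can be said about how compound 1 compares with compound 2 or compound 3 in this assay.

The unmeasured compound is compound 4, `Cc1cnc(-c2cc(Oc3cnc(C(=O)N(C)C)nc3)cc(OC(C)C)c2)[nH]c1=O`. It differs from compound 1 in a single place: methyl in place of hydrogen on an aromatic carbon. The shared core and the rest of the molecule are otherwise unchanged.

Going by the values given here, with no step between measured compounds to go on, the expectation rests only on the size of the change, which is small. A step from compound 1 to compound 4 of the size a 1.3-fold higher number from compound 1 to compound 4 (0.10 log units; within the scatter) is expected, that is, no change beyond the usual scatter of this assay. For compound 4 the apparent permeability is estimated at 9 10^-6 cm/s, with a likely range from 5 10^-6 cm/s to 17 10^-6 cm/s.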

Compound 4, apparent permeability: 11 10^-6 cm/s
Estimate against measurement, compound 4: 1.2-fold (0.09 log units) below; measured number inside the range.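

In this assay, for the compounds shown here, the change of hydrogen to methyl gives a 1.5-fold higher number from compound 1 to compound 4 (0.19 log units; within the scatter) and so provides the first step that can be read in this small set. Going by these compounds alone, the earlier compounds offered only the single number of compound 1 and said nothing about this aromatic carbon, ortho to a group of 1 heavy atom, two atoms from the ring nitrogen and para to a large group; the result now shows that this position takes a methyl without a shift in apparent permeability beyond the usual scatter. The data shown offer no measurement that would explain this outcome.

From the compounds shown here alone, one small carbon group at one position is all that this step covers, so it remains open whether a longer chain, a methoxy group, an amine or a carboxylic acid on the same carbon would also stay within the scatter. No step can be read for compound 2 or compound 3, which leaves open how the groups that differ in those two compounds bear on the read-out, alone or together with the methyl of compound 4.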